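From an Oxazole Ring to an Open Chain

The compounds below may be only part of what the source reports. "The series", "measured", "known", "first", "only" and "open" are said of these compounds alone.

Compound 1 `c1ccc(-c2cnco2)c(NCC2=NCCN2)c1` stands second highest of the three numbers in a functional assay for activation of Alpha-1A adrenergic receptor (Homo sapiens), read by calcium flux (on this read-out higher numbers stand for an effect only at larger amounts of compound and lower numbers for an effect already at smaller amounts), at 17.4 nM. Compound 2 `Cc1cc(-c2ccccc2NCC2=NCCN2)on1` gives 38.9 nM, and compound 3 `c1ccc(-c2cnccn2)c(NCC2=NCCN2)c1` gives 4.57 nM; the steps are a 2.2-fold higher number from compound 1 to compound 2 (0.35 log units; beyond the scatter) and a 3.8-fold lower number from compound 1 to compound 3 (0.58 log units; beyond the scatter). Compound 4 `CCO/N=C(\C)c1ccccc1NCC1=NCCN1` differs from compound 1 by a group of 6 heavy atoms (4 carbon, 1 nitrogen, 1 oxygen; no ring) in place of a group of 5 heavy atoms (3 carbon, 1 nitrogen, 1 oxygen; one five-membered aromatic ring with 2 hetero atoms), on an aromatic carbon. Both measured steps exchange the 1,3-oxazol-5-yl for another aromatic ring, and none replaces it with a group that has no ring, so they bear only loosely on this change, though they show that exchanges at this carbon shift the numbers modestly in either direction. For compound 4 a modest step is expected, a 1.7-fold higher number from compound 1 to compound 4 (0.24 log units; within the scatter), more likely toward a higher number. Compound 4 is therefore estimated at 30 nM, within 8 nM to 120 nM.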

Compound 4, half-maximal effective concentration: 52.5 nM
Beside the measured number, compound 4's estimate is 1.8-fold (0.24 log units) below it; low and high end bracket the measured number.
By their numbers in this assay, from the lowest: compound 3; then compound 1; then compounds 2 and 4 (each within the scatter of the next).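

In this assay, a group with no ring on this aromatic carbon still gives a value in the same range as the ring-bearing compounds, so a ring here is not required for activity (in a 3.0-fold higher number from compound 1 to compound 4 (0.48 log units; beyond the scatter)). The pyrazin-2-yl group stands clearly apart from the open chain (an 11-fold higher number from compound 3 to compound 4 (1.06 log units; beyond the scatter)), whereas the 3-methyl-1,2-oxazol-5-yl group does not (a 1.3-fold higher number from compound 2 to compound 4 (0.13 log units; within the scatter)). No evidence at hand explains these differences. With a single open chain shown, it remains open how far the result holds for other groups without a ring. An amine, a carboxylic acid or a longer alkyl chain on this carbon could read quite differently.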